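The source may hold more compounds than are shown below. What is called first, only, known or untested is meant among the compounds shown, and "the series" means these compounds.

Measured in an in vitro ADME assay on microsomes from liver (Mus musculus) for pharmacokinetics, read by LC-MS, with a stated time of 10 min, tested at 1 uM; on this read-out higher numbers stand for fast clearance and lower numbers for slow clearance:
compound 1 `CN1C[C@H](C(=O)Nc2ccc(C3CC3)cc2)[C@@H](c2ccc(/C=C/C(=O)Nc3ccccc3N)cc2)C1` gives 60 mL/min/kg
compound 2 `CCN1C[C@H](C(=O)Nc2ccc(Cl)cc2)[C@@H](c2ccc(/C=C/C(=O)Nc3ccccc3N)cc2)C1` gives 35 mL/min/kg
compound 3 `CC(C)N1C[C@H](C(=O)Nc2ccc(Cl)cc2)[C@@H](c2ccc(/C=C/C(=O)Nc3ccccc3N)cc2)C1` gives 38 mL/min/kg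

Compound 3 stands second highest of the three numbers in this assay; compound 2 is nearest and compound 1 furthest, and both gaps lie within the scatter, so the three values are not separable here.

Compound 4 `Nc1ccccc1NC(=O)/C=C/c1ccc([C@H]2CN(C3COC3)C[C@@H]2C(=O)Nc2ccc(Cl)cc2)cc1` differs from compound 3 in one place: oxetan-3-yl in place of isopropyl on an amine nitrogen in a ring. Within the data shown here, the only measured step at the same ring nitrogen is a 1.1-fold higher number from compound 2 to compound 3 (0.04 log units; within the scatter), which lies within the scatter. Among the measured compounds shown here, no measured step exchanges a chain for a ring at this position, so the direction is uncertain; a step of modest size, if any, is expected, a 1.4-fold lower number from compound 3 to compound 4 (0.13 log units; within the scatter). Compound 4 is therefore estimated at 28 mL/min/kg, range 14 mL/min/kg to 55 mL/min/kg.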

Compound 4, clearance: 42 mL/min/kg
Estimate against measurement, compound 4: 1.5-fold (0.18 log units) below; low and high end bracket the measured number.
By their numbers in this assay, from the lowest: compounds 2, 3, 4 and 1 (each within the scatter of the next).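

At the amine nitrogen in the ring, a ring substituent now stands alongside the chains: in this assay, oxetan-3-yl in place of isopropyl gives a 1.1-fold higher number from compound 3 to compound 4 (0.04 log units; within the scatter), and oxetan-3-yl in place of ethyl gives a 1.2-fold higher number from compound 2 to compound 4 (0.08 log units; within the scatter). With the (4-chlorophenyl)carbamoyl group held constant, ethyl, isopropyl and oxetan-3-yl therefore cannot be separated on clearance. No available evidence bears on this result.

Open, going by these compounds, is whether an acetyl or benzyl group on this nitrogen would give a step beyond the scatter. Also open, on these data alone, is whether oxetan-3-yl gives the same result with the cyclopropyl group of compound 1 in place of the chlorine.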